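This account rests on a few compounds, and the source may have more. Where it says the series, first, only, none or still open, it means among the compounds named here.

Compound 1 `O=C1c2c[n+]([O-])c3ccccc3c2C(=O)c2c1c1ccccc1n2Cc1cn([C@H]2C[C@H](O)[C@@H](CO)O2)nn1` and compound 2 `CN(C)CCCCn1c2c(c3ccccc31)C(=O)c1c[n+]([O-])c3ccccc3c1C2=O` share a core and differ in the group on its indole-type nitrogen. In a toxicity assay on L02 cells (Homo sapiens) for cytotoxicity, read by MTT assay, with a stated time of 72 h (on this read-out lower numbers stand for stronger inhibition and higher numbers for weaker inhibition), compound 1 gives 280 nM, and compound 2 gives 300 nM; these two numbers lie within the usual scatter of each other, so no difference between them can be claimed. Compound 3 `CC1(C)OC[C@H](Cn2cc(Cn3c4c(c5ccccc53)C(=O)c3c[n+]([O-])c5ccccc5c3C4=O)nn2)O1` keeps the triazole link of compound 1 but changes what hangs on the aromatic nitrogen: (2,2-dimethyl-1,3-dioxolan-4-yl)methyl in place of 4-hydroxy-5-(hydroxymethyl)oxolan-2-yl on an aromatic nitrogen. Among the compounds with values here, no measured pair shows what such a swap does. A small step is expected, a 1.3-fold higher number from compound 1 to compound 3 (0.10 log units; within the scatter), in no firm direction beyond the scatter. Compound 3 is therefore estimated at 350 nM, with a likely range from 120 nM to 1000 nM.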

Compound 3, half-maximal inhibitory concentration: 470 nM
Compound 3: the middle estimate sits 1.3-fold (0.13 log units) below what was measured; low and high end bracket the measured number.
By their numbers in this assay, from the lowest: compounds 1, 2 and 3 (each within the scatter of the next).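

Swapping 4-hydroxy-5-(hydroxymethyl)oxolan-2-yl for (2,2-dimethyl-1,3-dioxolan-4-yl)methyl on this aromatic nitrogen gives, in this assay, a 1.7-fold higher number from compound 1 to compound 3 (0.22 log units; within the scatter), so no real difference can be claimed. At this position, then, going from 2 hydrogen-bond donors to 0 and from 3 defined stereocentres to 1 leaves the number within the scatter. Nothing measured here explains this outcome.

As far as these compounds go, whether a simple amine or a carboxylic acid on this same nitrogen would shift the number beyond the scatter remains open.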